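Aryl swap on the triazole of compound 3

The source may report more compounds than this note shows. Statements on the series, on what has been measured and on what is new or still open speak of the compounds shown alone.

In a functional assay on MCF7 cells (Homo sapiens) for antiproliferative activity, read by MTT assay, with a stated time of 48 h (a lower number here means a stronger inhibitor, a higher number a weaker inhibitor), compound 3 `CCc1cccc(C)c1-n1nncc1CN1C(=O)C2(C(C#N)=C(N)Oc3c(N)cc4nc5ccccc5nc4c32)c2ccccc21` gives only a limit of the assay, > 50000 nM, and no number. Compound 1 `N#CC1=C(N)Oc2c(N)cc3nc4ccccc4nc3c2C12C(=O)N(Cc1cnnn1-c1ccc(Cl)cc1)c1ccccc12` likewise returns a limit in this assay, > 50000 nM. Going by the values given here, compound 2 `N#CC1=C(N)Oc2c(N)cc3nc4ccccc4nc3c2C12C(=O)N(Cc1cnnn1-c1ccccc1Cl)c1ccccc12` is the single member with a read number in this assay, 34400 nM. The steps between them are small where they can be read at all: an at least 1.4-fold lower number from compound 1 to compound 2 (0.16 log units; that floor lies within the scatter), an at least 1.4-fold higher number from compound 2 to compound 3 (0.16 log units; that floor lies within the scatter), and a step that the two limits leave unreadable from compound 1 to compound 3. Across these three compounds the limit of > 50000 nM in this assay, at which 2 of the 3 values shown sit, leaves most of the ground unseen.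

Compound 4 `N#CC1=C(N)Oc2c(N)cc3nc4ccccc4nc3c2C12C(=O)N(Cc1cnnn1-c1c(F)cccc1F)c1ccccc12` differs from compound 3 in one place: 2,6-difluorophenyl in place of 2-ethyl-6-methylphenyl on an aromatic nitrogen. The two readable aryl swaps, an at least 1.4-fold lower number from compound 1 to compound 2 (0.16 log units; that floor lies within the scatter) and an at least 1.4-fold higher number from compound 2 to compound 3 (0.16 log units; that floor lies within the scatter), both stayed within the scatter, so the step expected in this assay is an at least 1.1-fold lower number from compound 3 to compound 4 (0.04 log units; that floor lies within the scatter), with no movement beyond the scatter. Compound 4 is therefore estimated at 45000 nM in this assay, between 20000 nM and 100000 nM, and it may well come back again as only a limit.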

Compound 4, half-maximal inhibitory concentration: > 50000 nM
Compound 4: no number, only a limit; the forecaster's own chance of this, stated with the estimate: 55%; middle value at least 1.1-fold (0.04 log units) from the limit.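

In this assay compound 4 gives > 50000 nM, which is a limit of the assay and not a number. The 2,6-difluorophenyl group on the aromatic nitrogen yields an at least 1.4-fold higher number from compound 2 to compound 4 (0.16 log units; that floor lies within the scatter), so this swap shows no movement beyond the scatter, and the steps from compound 1 and compound 3 to compound 4 cannot be read. Fluorine now joins chlorine and the alkyl groups on this aryl ring without separating the series, compound 2 remains the only member with a read number, and the limit covers more of the set: the limit of > 50000 nM in this assay, at which 3 of the 4 values shown sit.

Going by these compounds, whether a group other than a substituted phenyl at this place, such as an amine on a longer chain or a carboxylic acid, would give a clearly lower read number in this assay remains open. On these data alone, how far compound 1, compound 3 and compound 4 lie past the limit, and so how they rank against one another, also remains open.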